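The source may report more compounds than this note shows. Statements on the series, on what has been measured and on what is new or still open speak of the compounds shown alone.

Working notes on the series. Three compounds carry a number in a physicochemical assay for lipophilicity, read by HPLC, at pH 7.4; a higher number here means a more lipophilic compound, a lower number a more polar compound. Compound 1 `COC(=O)N[C@H](C(=O)N1CCC[C@H]1C(=O)Nc1ccc([C@@H]2CC[C@@H](c3ccc(NC(=O)[C@@H]4CCCN4C(=O)[C@@H](NC(=O)OC)[C@@H](C)OC)cc3)N2c2ccc(F)cc2)cc1)[C@@H](C)OC` gives 3. Compound 2 `COC(=O)N[C@H](C(=O)N1CCC[C@H]1C(=O)Nc1ccc([C@H]2CC[C@H](c3ccc(NC(=O)[C@@H]4CCCN4C(=O)[C@@H](NC(=O)OC)C(C)C)cc3)N2c2ccc(C(F)(F)F)cc2)cc1)C(C)C` gives 4.9. Compound 3 `COC(=O)N[C@H](C(=O)N1CCC[C@H]1C(=O)Nc1ccc([C@@H]2CC[C@@H](c3ccc(NC(=O)[C@@H]4CCCN4C(=O)[C@@H](NC(=O)OC)[C@H]4CCOC4)cc3)N2c2ccc(F)cc2)cc1)[C@H]1CCOC1` gives 3.2. On these numbers compound 3 stands second highest of the three: compound 1 lies nearest, within the scatter, so the two are not separated; compound 2 lies furthest, beyond the scatter, on the more lipophilic side. Within the data shown here, no pair of measured compounds differs in a single place, so no measured step is available in this assay.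

Compound 4 `COC(=O)N[C@H](C(=O)N1CCC[C@H]1C(=O)Nc1ccc([C@H]2CC[C@H](c3ccc(NC(=O)[C@@H]4CCCN4C(=O)[C@@H](NC(=O)OC)[C@H]4CCOC4)cc3)N2c2ccc(F)cc2)cc1)[C@H]1CCOC1` has not yet been measured in this assay. How it differs from compound 3: the two compounds have the same atoms and bonds and differ only in configuration as drawn: 2 of 8 stereo elements differ; a stereocentre at a saturated ring carbon is drawn S in compound 3 and R in compound 4; a stereocentre at a saturated ring carbon is drawn S in compound 3 and R in compound 4 Same atoms and same bonds, only configuration as drawn changes. Among the measured compounds shown here, no measured pair shows what a change of configuration alone does in this assay. The expectation is that the number for compound 4 stays close to that of compound 3, and the step from compound 3 to compound 4 is estimated as no change at the digits printed from compound 3 to compound 4 (within the scatter), none beyond the scatter. Compound 4 is therefore expected at 3.2, in a range from 2.9 to 3.5.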

Compound 4, distribution coefficient: 3.2
For compound 4 middle estimate and measured number coincide at the digits printed; measured number inside the range.
By their numbers in this assay, from the lowest: compounds 1, 3 and 4 (each within the scatter of the next); then compound 2.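

The series now holds its first measured step in this assay, and it concerns configuration alone, with no change at the digits printed from compound 3 to compound 4 (within the scatter) at the two saturated ring carbons drawn S in the first compound and R in the second. This comparison isolates a single kind of change: the fact that compounds 3 and 4 differ only in the configuration as drawn. Among these compounds, for this pair, reversing both stereocentres as drawn does not separate the two compounds in this assay, and this reading extends to no other compound.

The compounds shown leave open whether reversing only one of these stereocentres, or reversing both on the frame of compound 1 or compound 2, would read the same way. They also leave open what a single replacement on the shared core, such as an amine or a carboxylic acid in place of the fluorine, would do in this assay.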